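Amino to hydroxy with every reading at the limit

The source may hold more compounds than are shown below. What is called first, only, known or untested is meant among the compounds shown, and "the series" means these compounds.

compound 1 `Cc1cn([C@H]2C[C@H](CF)[C@@H](CO)O2)c(=O)[nH]c1=O` gives > 100 uM (a limit)
compound 2 `Cc1cn([C@@H]2O[C@H](CO)[C@@H](CO)[C@H]2O)c(=O)[nH]c1=O` gives > 100 uM (a limit)
compound 3 `Cc1cn([C@H]2C[C@H](CN)[C@@H](CO)O2)c(=O)[nH]c1=O` gives > 100 uM (a limit)
compound 4 `Cc1cn([C@H]2C[C@H](CO)[C@@H](CO)O2)c(=O)[nH]c1=O` is not yet measured

All three readings come from a functional assay on L1210 cells (Mus musculus) for antiproliferative activity, with a stated time of 72 h (a lower number here means that less compound is needed, a higher number that more compound is needed for the effect), and none of them is a true number. Compound 3 reports only a limit, > 100 uM, and so offers no exact starting point. The same picture holds across the series, as the limit of > 100 uM in this assay, at which 3 of the 3 values shown sit, shows.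

The next change replaces amino with hydroxy on a saturated chain carbon bound to a saturated ring carbon (hydroxy in place of amino on a saturated chain carbon bound to a saturated ring carbon). Cut one bond further out, this reads aminomethyl to hydroxymethyl.

One measured change touches the same place, with amino in place of fluoro: a step that the two limits leave unreadable from compound 1 to compound 3. That step gives no size to carry forward, and no direction either.

With compound 3 at > 100 uM, which is a limit, no step beyond the scatter is expected in this assay. The expected result is a step that the limit leaves unreadable from compound 3 to compound 4. For compound 4 the estimate is 150 uM, with an expected range from 60 uM to 400 uM, and the assay will most likely report only a limit again.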

Compound 4, concentration for half-maximal effect: 50 uM
Estimate against measurement, compound 4: 3.0-fold (0.48 log units) above; measured number below the stated range.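

Compound 4 is the first compound shown with a true number in this assay and so gives this place its first readable steps: hydroxy in place of amino on a saturated chain carbon bound to a saturated ring carbon gives an at least 2.0-fold lower number from compound 3 to compound 4 (0.30 log units; that floor lies within the scatter) and points in a direction that the earlier compounds could not show. Hydroxy in place of fluoro at the same place gives an at least 2.0-fold lower number from compound 1 to compound 4 (0.30 log units; that floor lies within the scatter) and hydrogen in place of hydroxy on a saturated ring carbon gives an at least 2.0-fold lower number from compound 2 to compound 4 (0.30 log units; that floor lies within the scatter) so compound 4 has the lower number against each of its three neighbours, though each step is known only as a floor. That floor is all that can be read, since the other end of each step is a limit and the series mostly stays at the edge of what the assay reports: the limit of > 100 uM in this assay, at which 3 of the 4 values shown sit.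

As far as these compounds go, how far compounds 1, 2 and 3 really lie from compound 4 stays open, and with it the true size of all three steps. Also open, from the compounds shown here alone, is whether a carboxylic acid, a methoxy group or a longer chain in place of the hydroxymethyl would lower the number further.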